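Series notes: aryl ether macrolides, methoxy to hydroxy step

A few compounds are considered here, and "the series" means these few. Any claim that something is new, unique, unknown or untested is made for them only; others in the source may bear on it.

Measured so far:
Compound 1, `CC[C@@H]1/C=C(\C)C[C@H](C)C[C@H](OC)[C@H]2O[C@@](O)(C(=O)C(=O)N3CCCC[C@H]3C(=O)O[C@H](/C(C)=C/[C@@H]3CC[C@@H](Oc4cccc(C)c4)[C@H](OC)C3)[C@H](C)[C@@H](O)CC1=O)[C@H](C)C[C@@H]2OC` — 5.4 nM
Compound 2, `CC[C@@H]1/C=C(\C)C[C@H](C)C[C@H](OC)[C@H]2O[C@@](O)(C(=O)C(=O)N3CCCC[C@H]3C(=O)O[C@H](/C(C)=C/[C@@H]3CC[C@@H](Oc4ccc(O)cc4)[C@H](OC)C3)[C@H](C)[C@@H](O)CC1=O)[C@H](C)C[C@@H]2OC` — 0.8 nM

Both numbers come from a functional assay on cells for inhibition, with Murine T-cell line (Mus musculus) as the target; on this read-out higher numbers stand for weaker inhibition and lower numbers for stronger inhibition. Within the data shown here, the one step measured within the pair is a 6.8-fold lower number from compound 1 to compound 2 (0.83 log units; beyond the scatter). On the numbers shown, compound 2 stands at the lowest value; its nearest neighbour, compound 1, lies beyond the scatter above it.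

Compound 3, `CC[C@@H]1/C=C(\C)C[C@H](C)C[C@H](OC)[C@H]2O[C@@](O)(C(=O)C(=O)N3CCCC[C@H]3C(=O)O[C@H](/C(C)=C/[C@@H]3CC[C@@H](Oc4ccc(O)cc4)[C@H](O)C3)[C@H](C)[C@@H](O)CC1=O)[C@H](C)C[C@@H]2OC`, is not yet measured. It differs from compound 2 as follows: hydrogen in place of methyl on an oxygen on a saturated carbon. Among the measured compounds shown here, no measured step in this set touches that oxygen on the saturated ring carbon; the single step from compound 1 to compound 2 concerns the aryl group, so it does not bear on this change. With nothing to lean on, the expectation for this assay is a step near zero, a 1.3-fold higher number from compound 2 to compound 3 (0.10 log units; within the scatter), not beyond the scatter in either direction. Compound 3 is therefore estimated at 1 nM, with a range from 0.35 nM to 3 nM.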

Compound 3, half-maximal inhibitory concentration: 1.6 nM
For compound 3 the middle estimate is 1.6-fold (0.20 log units) below the measured one; measured number inside the range.
By their numbers in this assay, from the lowest: compounds 2 and 3 (each within the scatter of the next); then compound 1.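

In this assay, the methoxy to hydroxy change on the saturated ring carbon gives a 2.0-fold higher number from compound 2 to compound 3 (0.30 log units; within the scatter) and so leaves compound 2 and compound 3 indistinguishable on this read-out. Among these compounds, this is the first reading at this oxygen, as the earlier step concerned only the aryl group, and it shows that with the 4-hydroxyphenyl ether in place, the methyl on this oxygen can give way to hydrogen without a change beyond the scatter. Nothing available here offers an explanation for this outcome.

From the compounds shown here alone, whether the same holds with the 3-methylphenyl ether of compound 1 remains open. Also open, going by these compounds, is how this position would respond to an ethyl group or a longer chain on the oxygen, or to an amine in place of the hydroxy group.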